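The compounds below may be only part of what the source reports. "The series", "measured", "known", "first", "only" and "open" are said of these compounds alone.

Compound 1 `N#CC1=C(N)Oc2c(c3nc4ccccc4nc3c3ccccc23)C12C(=O)N(Cc1cnnn1-c1ccc(Cl)cc1)c1ccccc12`: in a functional assay on A549 cells (Homo sapiens) for antiproliferative activity, read by MTT assay, with a stated time of 48 h (a lower number here means a stronger inhibitor, a higher number a weaker inhibitor), compound 1 gives > 50000 nM, which is a limit of the assay and not a number. Compound 2 `N#CC1=C(N)Oc2c(c3nc4ccccc4nc3c3ccccc23)C12C(=O)N(Cc1cnnn1-c1ccccc1Cl)c1ccccc12`: compound 2 gives 42600 nM. Compound 3 `N#CC1=C(N)Oc2c(c3nc4ccccc4nc3c3ccccc23)C12C(=O)N(Cc1cnnn1-c1cccc(Cl)c1)c1ccccc12`: compound 3 gives 32600 nM.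

Compound 3 has the smallest of the two numbers shown, but its nearest neighbour is compound 2 and the step of a 1.3-fold lower number from compound 2 to compound 3 (0.12 log units; within the scatter) lies within the scatter, so the two cannot be told apart. Compound 4 `COc1ccc(-n2nncc2CN2C(=O)C3(C(C#N)=C(N)Oc4c3c3nc5ccccc5nc3c3ccccc43)c3ccccc32)cc1` differs from compound 3 in one place: 4-methoxyphenyl in place of 3-chlorophenyl on an aromatic nitrogen. The measured steps all move a chlorine around the same phenyl ring: an at least 1.1-fold lower number from compound 1 to compound 2 (0.06 log units; that floor lies within the scatter), an at least 1.5-fold lower number from compound 1 to compound 3 (0.18 log units; that floor lies within the scatter) and a 1.3-fold lower number from compound 2 to compound 3 (0.12 log units; within the scatter), with compound 1 sitting at the limit of > 50000 nM in this assay, at which 1 of the 3 values shown sits. None of them reaches beyond the scatter, and none brings in a methoxy group, so the change to compound 4 is expected to leave the number roughly where compound 3 stands. Compound 4 is expected to give about 30000 nM, with a range from 12000 nM to 70000 nM. The expected step of a 1.1-fold lower number from compound 3 to compound 4 (0.04 log units; within the scatter) thus stays within the scatter.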

Compound 4, half-maximal inhibitory concentration: > 50000 nM
Compound 4 was reported as a limit; the forecaster's own chance of this, stated with the estimate: 25%; at least 1.6-fold (0.22 log units) between middle value and limit.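

Among the compounds shown here, compound 4 is the first compound here to carry something other than chlorine on the phenyl ring, and its result is a limit and not a number: the limit of > 50000 nM in this assay, at which 2 of the 4 values shown sit. Set against the two chlorophenyl compounds that have numbers, the change gives an at least 1.5-fold higher number from compound 3 to compound 4 (0.18 log units; that floor lies within the scatter) and an at least 1.1-fold higher number from compound 2 to compound 4 (0.06 log units; that floor lies within the scatter), so the 4-methoxyphenyl group brings no visible gain, though these floors alone cannot establish a real loss. The step between compound 1 and compound 4 cannot be read, as both results are limits.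

Still open, on these data alone, is whether methoxy placed elsewhere on this ring would behave the same way. Also open, as far as these compounds go, is whether a different substituent on the phenyl ring, such as an amine or a carboxylic acid, would bring the number down.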